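Methyl to Ethyl on the Core of Compound 3

The source may hold more compounds than are shown below. What is called first, only, known or untested is meant among the compounds shown, and "the series" means these compounds.

Of the compounds shown here, three built on the same core have been tested in an ADME assay on cells (Homo sapiens) for cytotoxicity, read by polymerase chain reaction, with a stated time of 3 days; on this read-out lower numbers stand for higher toxicity in this test and higher numbers for lower toxicity in this test. Compound 1 `CNc1nc(C)c(-c2nc3ccccc3s2)c(N[C@@H]2C[C@H](CO)[C@@H](O)[C@H]2O)n1` gives > 25000 nM, which is a limit of the assay and not a number. Compound 2 `Cc1nc(NCC(C)C)nc(N[C@@H]2C[C@H](CO)[C@@H](O)[C@H]2O)c1-c1nc2ccccc2s1` gives 10000 nM, while compound 3 `Cc1nc(N(C)C)nc(N[C@@H]2C[C@H](CO)[C@@H](O)[C@H]2O)c1-c1nc2ccccc2s1` gives 18000 nM. Of the two numbers, compound 3 holds the higher one, yet the step of a 1.8-fold higher number from compound 2 to compound 3 (0.26 log units; within the scatter) lies within the scatter, so the pair cannot be separated. Both steps leading away from compound 1 set out from a limit (the limit of > 25000 nM in this assay, at which 1 of the 3 values shown sits).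

Compound 4 `CCc1nc(N(C)C)nc(N[C@@H]2C[C@H](CO)[C@@H](O)[C@H]2O)c1-c1nc2ccccc2s1` differs from compound 3 by methyl in place of hydrogen on a saturated chain carbon bound to an aromatic carbon. Among the compounds with values here, no measured step touches that place: the step of an at least 2.5-fold lower number from compound 1 to compound 2 (0.39 log units; beyond the scatter) added carbons on a chain carbon bound to a nitrogen, and the step of an at least 1.3-fold lower number from compound 1 to compound 3 (0.14 log units; that floor lies within the scatter) put a methyl on a nitrogen. Neither speaks directly to the present change, so the account expects no step beyond the scatter in this assay, amounting to no change at the digits printed from compound 3 to compound 4 (within the scatter). Compound 4 is accordingly estimated at 18000 nM, within a range from 8000 nM to 40000 nM.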

Compound 4, half-maximal cytotoxic concentration: > 25000 nM
Compound 4 ended at the assay's limit; the forecaster's own chance of this, stated with the estimate: 30%; at least 1.3-fold (0.14 log units) between middle value and limit.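

Within the data shown here, compound 3 and the earlier compounds all carry methyl at this place, so this is the first reading on the saturated chain carbon bound to an aromatic carbon. In this assay, methyl to ethyl gives an at least 1.3-fold higher number from compound 3 to compound 4 (0.14 log units; that floor lies within the scatter), which leaves no sign of a lower number at this place, although the full size of the step cannot be read. Compound 4 carries a limit and not a number: the limit of > 25000 nM in this assay, at which 2 of the 4 values shown sit.

The compounds shown leave open whether a longer chain such as propyl, or a hydroxymethyl or an amine at this place, would move the number beyond the scatter. They also leave open whether ethyl in place of methyl would read the same with the isobutylamino group of compound 2 on the core.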